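The source may report more compounds than this note shows. Statements on the series, on what has been measured and on what is new or still open speak of the compounds shown alone.

Of the compounds shown here, three built on one shared core have been tested in a functional assay on PC-3 cells (Homo sapiens) for cytotoxicity, read by MTT assay, with a stated time of 72 h; on this read-out higher numbers stand for weaker inhibition and lower numbers for stronger inhibition. Compound 1 `O=C(Nc1ccc(Oc2ccnc3[nH]ccc23)cc1)c1nccc(-c2ccc(F)cc2)n1` is reported in this assay as "not active" (no number reported). Compound 2 `COc1ccc(-c2cc(C(=O)Nc3ccc(Oc4ccnc5[nH]ccc45)cc3)ncn2)cc1` gives 9830 nM. Compound 3 `COc1ccc(-c2cc(C(=O)Nc3ccc(Oc4ccnc5[nH]ccc45)c(F)c3)ncn2)cc1` gives 2570 nM, the lowest of the two numbers reported; the step of a 3.8-fold lower number from compound 2 to compound 3 (0.58 log units; beyond the scatter) separates it from compound 2, and compound 1 contributes no number at all. Compound 4 `O=C(Nc1ccc(Oc2ccnc3[nH]ccc23)c(F)c1)c1cc(-c2ccc(Br)cc2)ncn1` has not yet been measured. It differs from compound 3 in a single place: bromo in place of methoxy on an aromatic carbon, which, read one bond further out, is the exchange of a 4-methoxyphenyl for a 4-bromophenyl, the new group sitting para to a large group. Among the measured compounds shown here, no measured step bears on this exchange; the only step in hand, a 3.8-fold lower number from compound 2 to compound 3 (0.58 log units; beyond the scatter), concerns a fluoro added elsewhere and says nothing about the methoxy. The expectation for compound 4 in this assay therefore rests on the numbers around it, and the step of a 1.2-fold higher number from compound 3 to compound 4 (0.07 log units; within the scatter) is expected to stay within the usual scatter. Compound 4 is estimated at 3000 nM, within a range from 800 nM to 12000 nM.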

Compound 4, half-maximal inhibitory concentration: 11300 nM
Estimate against measurement, compound 4: 3.8-fold (0.58 log units) below, and the stated range covers the measured number.
By their numbers in this assay, from the lowest: compound 3; then compounds 2 and 4 (each within the scatter of the next).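

In this assay, the exchange of a 4-methoxyphenyl for a 4-bromophenyl gives a 4.4-fold higher number from compound 3 to compound 4 (0.64 log units; beyond the scatter), the first measured sign that the group at this outer end of the molecule affects the read-out. The earlier step concerned only a fluoro elsewhere on the molecule, whereas this one shows that, with that fluoro in place, methoxy gives the lower number of these two groups at this position. Nothing measured here explains the difference, so the result records an effect without a reason.

As far as these compounds go, whether an amine, a hydroxyl or a longer chain such as ethoxy at this position would give a lower number than methoxy remains open. Also open, from the compounds shown here alone, is whether the same exchange would have a similar effect on a compound without that fluoro.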